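The source may report more compounds than this note shows. Statements on the series, on what has been measured and on what is new or still open speak of the compounds shown alone.

Compound 1 `COc1ccccc1C(=O)Nc1nnc(SCC(=O)Nc2ccc(Br)cn2)s1`: in a functional assay on A875 cells (Homo sapiens) for antiproliferative activity, read by MTT assay, with a stated time of 48 h (a higher number here means a weaker inhibitor, a lower number a stronger inhibitor), compound 1 gives > 80000 nM, which is a limit of the assay, not a number.
Compound 2 `COc1ccccc1C(=O)Nc1nnc(SCC(=O)Nc2ccc(C)cn2)s1`: in this assay compound 2 gives > 80000 nM, again a limit.
Compound 3 `COc1ccccc1C(=O)Nc1nnc(SCC(=O)Nc2ccc(Cl)cn2)s1`: in this assay compound 3 gives > 80000 nM, again a limit.

Compound 3 thus stands only at a limit, and every value shown sits at the same one (the limit of > 80000 nM in this assay, at which 3 of the 3 values shown sit). The steps a step that the two limits leave unreadable from compound 1 to compound 2, a step that the two limits leave unreadable from compound 1 to compound 3 and a step that the two limits leave unreadable from compound 2 to compound 3 therefore cannot be read. Compound 4 `COc1ccccc1C(=O)Nc1nnc(SCC(=O)Nc2c(C)ccnc2Cl)s1` differs from compound 3 by 2-chloro-4-methylpyridin-3-yl in place of 5-chloropyridin-2-yl on an amide-type nitrogen. Among the measured compounds shown here, no measured step bears on this change, and none of the measured steps has a readable size. Compound 4 is therefore expected to remain at the limit, with an estimated step that the limit leaves unreadable from compound 3 to compound 4. For compound 4 the estimate in this assay is 100000 nM, between 30000 nM and 300000 nM.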

Compound 4, half-maximal inhibitory concentration: > 80000 nM
Compound 4 gave a limit, no number; the forecaster's own chance of this, stated with the estimate: 85%; the middle value is on the limit's open side.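

Compound 4 also gives only a limit, so its steps to compound 1, compound 2 and compound 3 cannot be read, and all four compounds stand at the same point: the limit of > 80000 nM in this assay, at which 4 of the 4 values shown sit.

The compounds shown leave open what potency any of them has in this assay and which structural change would bring a measurable value.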